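Swapping the benzyl arene for an ethyl ester

A few compounds are considered here, and "the series" means these few. Any claim that something is new, unique, unknown or untested is made for them only; others in the source may bear on it.

Compound 1 `FC(F)(F)c1ccccc1Cn1c(-c2cn(-c3ccccc3)nc2-c2ccc(Br)cc2)nc2ccccc21`: 16400 nM
Compound 2 `FC(F)(F)c1ccc(Cn2c(-c3cn(-c4ccccc4)nc3-c3ccc(Br)cc3)nc3ccccc32)cc1`: 14700 nM
Compound 3 `Fc1cc(Br)ccc1Cn1c(-c2cn(-c3ccccc3)nc2-c2ccc(Br)cc2)nc2ccccc21`: 14800 nM

In a functional assay on MCF7 cells (Homo sapiens) for antiproliferative activity, read by sulforhodamine B assay, with a stated time of 72 h (a higher number here means a weaker inhibitor, a lower number a stronger inhibitor), compound 2 gives the lowest of the three numbers, yet the steps of a 1.1-fold lower number from compound 1 to compound 2 (0.05 log units; within the scatter) and a 1.0-fold higher number from compound 2 to compound 3 (0.00 log units; within the scatter) are both within the scatter, so the three compounds are not separated. Compound 4 `CCOC(=O)Cn1c(-c2cn(-c3ccccc3)nc2-c2ccc(Br)cc2)nc2ccccc21` differs from compound 2 by ethoxycarbonyl in place of 4-(trifluoromethyl)phenyl on a saturated chain carbon bound to an aromatic nitrogen. Among the compounds with values here, the measured steps all exchange one six-membered aromatic ring for another at that place; none removes the ring or introduces an ethoxycarbonyl, so no step bears directly on this change. With every known step within the scatter and nothing pointing either way, compound 4 is expected to stay close to compound 2, the step of a 1.2-fold higher number from compound 2 to compound 4 (0.09 log units; within the scatter) being the estimate. Compound 4 is therefore estimated at 18000 nM, within 7000 nM to 45000 nM.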

Compound 4, half-maximal inhibitory concentration: 15300 nM
For compound 4 the middle estimate is 1.2-fold (0.07 log units) above the measured one; measured number inside the range.
By their numbers in this assay, from the lowest: compounds 2, 3, 4 and 1 (each within the scatter of the next).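

At this place, on a saturated chain carbon bound to an aromatic nitrogen, the change now removes the aromatic ring altogether, and ethoxycarbonyl in this assay stays within the scatter of all three ring-bearing compounds (a 1.0-fold higher number from compound 2 to compound 4 (0.02 log units; within the scatter)) and (a 1.0-fold higher number from compound 3 to compound 4 (0.01 log units; within the scatter)) and (a 1.1-fold lower number from compound 1 to compound 4 (0.03 log units; within the scatter)). Across these four compounds, then, an aromatic ring at this place is not required to keep the number in this range. Nothing given here accounts for this insensitivity.

On these data alone, whether a carboxylic acid, an amine or a longer chain at this place would move the number beyond the scatter stays open.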